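The source may hold more compounds than are shown below. What is called first, only, known or untested is meant among the compounds shown, and "the series" means these compounds.

Measured so far in a functional assay on HeLa cells for antagonist activity at 5-hydroxytryptamine receptor 6 (Homo sapiens), read by cAMP accumulation and immunoassay; on this read-out lower numbers stand for smaller maximal responses and higher numbers for larger maximal responses:
compound 1 `CC(C)N1CCCC(n2cc(S(=O)(=O)C3=C(Cl)NC4SC=CN34)c3cccnc32)C1`; compound 1 gives 65%
compound 2 `O=S(=O)(c1ccc(Cl)cc1)c1cn(C2CCCNC2)c2ncccc12`; compound 2 gives 76%

On these two numbers compound 2 stands highest. Its nearest neighbour, compound 1, lies lower by a gap that is beyond the usual scatter; the two differ in more than one place, so nothing further is drawn from that gap.

Compound 3 `CN1CCCC(n2cc(S(=O)(=O)c3ccc(Cl)cc3)c3cccnc32)C1` is not yet measured. It differs from compound 2 in a single place: methyl in place of hydrogen on an amine nitrogen in a ring. Going by the values given here, no pair of measured compounds differing in one place exists in this set, so the size of such a step in this assay has no precedent here. With only a methyl entering on the amine nitrogen in the ring, the expectation is a change no larger than the scatter, in either direction. Compound 3 is therefore expected to give 72% in this assay, with a range of 56% to 88%. The estimated step of a number 4 percentage points lower from compound 2 to compound 3 (within the scatter) is expected to stay within the scatter.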

Compound 3, largest response reached (reported as Imax), in percent of the reference or control that the assay uses: 63%
For compound 3 the middle estimate is 9 percentage points above the measured one, and the stated range covers the measured number.
By their numbers in this assay, from the lowest: compounds 3 and 1 (each within the scatter of the next); then compound 2.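

In this assay, the amine nitrogen of the piperidin-3-yl group proves sensitive to substitution: methyl in place of hydrogen there gives a number 13 percentage points lower from compound 2 to compound 3 (beyond the scatter). Going by these compounds alone, this is the first single-place step, so the size of a change at this position can now be read, and even one added carbon on this nitrogen moves the maximal response by more than the scatter with the rest of the structure unchanged. Nothing available explains this drop in the number.

As far as these compounds go, whether an ethyl group or a longer chain on the same nitrogen would lower the number further remains open. So does whether an acetyl group there, which removes the amine character of this nitrogen, would give a step of similar size.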